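Inverting one stereocentre in a small stereoisomer series

The source may report more compounds than this note shows. Statements on the series, on what has been measured and on what is new or still open speak of the compounds shown alone.

- Compound 1 `Nc1ncn(C[C@@H]2CO[C@H](CO)O2)c(=O)n1` gives 20000 nM in a functional assay on CCRF-CEM cells (Homo sapiens); on this read-out higher numbers stand for an effect only at larger amounts of compound and lower numbers for an effect already at smaller amounts
- Compound 2 `Nc1ncn(C[C@H]2CO[C@H](CO)O2)c(=O)n1` gives 30000 nM in the same test
- Compound 3 `Nc1ncn(C[C@H]2CO[C@@H](CO)O2)c(=O)n1` gives 80000 nM in the same test

Compound 3 has the highest number of the three, as shown by a 2.7-fold higher number from compound 2 to compound 3 (0.43 log units; beyond the scatter) and by a 4.0-fold higher number from compound 1 to compound 3 (0.60 log units; beyond the scatter) in this assay. Compound 4 `Nc1ncn(C[C@@H]2CO[C@@H](CO)O2)c(=O)n1` has not yet been measured. It is reached by one change: the two compounds have the same atoms and bonds and differ only in configuration as drawn: 1 of 2 stereo elements differ; a stereocentre at a saturated ring carbon is drawn S in compound 3 and R in compound 4. Two measured steps also alter a single stereocentre, namely a 1.5-fold higher number from compound 1 to compound 2 (0.18 log units; within the scatter) and a 2.7-fold higher number from compound 2 to compound 3 (0.43 log units; beyond the scatter). These steps are small to modest, and even inverting both centres gives only a 4.0-fold higher number from compound 1 to compound 3 (0.60 log units; beyond the scatter) as its shift. Compound 3 already sits at 80000 nM at the top of the series, so a further single inversion is expected to lower the number slightly rather than raise it. The expected change is a 1.8-fold lower number from compound 3 to compound 4 (0.25 log units; within the scatter) in this assay as a small downward step. For compound 4 the estimated value is 45000 nM with an expected range from 18000 nM to 100000 nM when it is measured.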

Compound 4, half-maximal effective concentration: 70000 nM
Compound 4: middle estimate off by 1.6-fold (0.19 log units), on the low side; low and high end bracket the measured number.
By their numbers in this assay, from the lowest: compounds 1 and 2 (each within the scatter of the next); then compounds 4 and 3 (each within the scatter of the next).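

In this assay, the stereocentre inverted in a 1.1-fold lower number from compound 3 to compound 4 (0.06 log units; within the scatter) is the same one that separates compound 1 from compound 2, and both inversions stay within the scatter, so this centre shows no readable effect under either configuration of the other centre. The other stereocentre now gives a shift beyond the scatter in a second setting, as a 3.5-fold higher number from compound 1 to compound 4 (0.54 log units; beyond the scatter) joins a 2.7-fold higher number from compound 2 to compound 3 (0.43 log units; beyond the scatter). The mirror-image pair adds a 2.3-fold higher number from compound 2 to compound 4 (0.37 log units; beyond the scatter), so compounds 1 and 2 stand apart from compounds 3 and 4 by the configuration of that second centre.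

On these data alone, all four compounds share the same atoms and bonds, so it remains open whether this split would persist with an amine or a carboxylic acid in place of the hydroxyl group. As far as these compounds go, what underlies the split also remains unknown.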